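A few compounds are considered here, and "the series" means these few. Any claim that something is new, unique, unknown or untested is made for them only; others in the source may bear on it.

Compound 1 `COc1ccc(-c2sc(C(=O)O)cc2-c2cc(OC)c(OC)c(OC)c2)cc1` gives 7800 nM
Compound 2 `COc1cc(-c2cc(C(=O)O)sc2-c2cccc(Br)c2)cc(OC)c1OC` gives 93400 nM
Compound 3 `COc1cc(-c2cc(C(=O)O)sc2-c2ccc3ccccc3c2)cc(OC)c1OC` gives 380 nM

These three values come from a functional assay on SGC-7901 cells (Homo sapiens) for antiproliferative activity, read by MTT assay, with a stated time of 72 h; on this read-out lower numbers stand for stronger inhibition and higher numbers for weaker inhibition. Compound 1, at 7800 nM, stands in the middle, with the second highest number of the three. Compound 4 `COc1ccc(-c2sc(C(=O)O)cc2-c2cc(OC)c(OC)c(OC)c2)cc1OCc1ccccc1` keeps everything in compound 1 and adds one group: benzyloxy in place of hydrogen on an aromatic carbon. In words, this is benzyloxy in place of hydrogen on an aromatic carbon, ortho to a methoxy group and meta to a large group.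

For the measured compounds named here, the only measured steps that bear on this change alter the same 4-methoxyphenyl group. Swapping it for 3-bromophenyl gives a 12-fold higher number from compound 1 to compound 2 (1.08 log units; beyond the scatter), while swapping it for naphthalen-2-yl gives a 21-fold lower number from compound 1 to compound 3 (1.31 log units; beyond the scatter). Both steps are large, but they run in opposite directions, and between the two replacements lies a 250-fold lower number from compound 2 to compound 3 (2.39 log units; beyond the scatter). Changes to this group can therefore matter a great deal, yet no measured compound carries benzyloxy, so the data do not settle the direction. The most reasonable expectation is no clear step beyond the scatter, with a wide margin on both sides. The expected step is a 1.6-fold lower number from compound 1 to compound 4 (0.19 log units; within the scatter). For compound 4 the estimated value is 5000 nM, with an expected range from 500 nM to 40000 nM.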

Compound 4, half-maximal inhibitory concentration: > 100000 nM
Compound 4 gave a limit, no number; the forecaster's own chance of this, stated with the estimate: 10%; middle value at least 20-fold (1.30 log units) from the limit.
By their numbers in this assay, from the lowest: compound 3; then compound 1; then compound 2. At a limit, above all of these: compound 4.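

In this assay, putting benzyloxy in place of hydrogen on an aromatic carbon, ortho to a methoxy group and meta to a large group, gives an at least 12-fold higher number from compound 1 to compound 4 (1.10 log units; beyond the scatter), so this position does not accept this group without a large loss of inhibition. For compound 4, the reading of > 100000 nM is a limit of the assay and not a number. The earlier steps shown here replaced the whole 4-methoxyphenyl group, and the one that brought in more aromatic rings gave a 21-fold lower number from compound 1 to compound 3 (1.31 log units; beyond the scatter), whereas this step keeps that group and adds a six-membered aromatic ring through an oxygen, which shows that an extra aromatic ring does not by itself bring stronger inhibition, with compound 3 as the case that goes the other way.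

The compounds shown leave open whether the loss belongs to the whole benzyloxy group or would also appear with something much smaller at this position, such as a hydroxyl, a fluorine or an ethoxy group. They also leave open whether an amine or a carboxylic acid at this position would restore inhibition, and how far compound 4 lies past its limit.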